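The compounds below may be only part of what the source reports. "The series", "measured", "known", "first", "only" and "open" are said of these compounds alone.

In a functional assay on K562 cells (Homo sapiens) for cytotoxicity (on this read-out lower numbers stand for stronger inhibition and higher numbers for weaker inhibition), compound 1 `CCC(CO)Nc1nc(NCc2ccccc2)c2nc(N)n(C(C)C)c2n1` gives 80000 nM. Compound 2 `CCC(CO)Nc1nc(NCc2ccccc2)c2nc(S)n(C(C)C)c2n1` gives 154000 nM. Among the compounds with values here, these two numbers lie within the scatter of each other, so compound 2 cannot be separated from the only other compound measured so far. Compound 3 `CCC(CO)Nc1nc(NCc2ccccc2)c2nc([N+](=O)[O-])n(C(C)C)c2n1` carries nitro in place of sulfanyl on an aromatic carbon, between two ring nitrogen atoms: nitro in place of sulfanyl on an aromatic carbon. Within the data shown here, one measured step bears on this same place, a 1.9-fold higher number from compound 1 to compound 2 (0.28 log units; within the scatter), and it stays within the scatter. Among the measured compounds shown here, no compound with nitro has been measured, so that single step is only indirect guidance. No step beyond the scatter is therefore expected in this assay, though the range is kept wide. The expected step is a 1.4-fold lower number from compound 2 to compound 3 (0.15 log units; within the scatter). For compound 3 the estimate is 110000 nM, with an expected range of 40000 nM to 300000 nM.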

Compound 3, half-maximal inhibitory concentration: 117000 nM
Compound 3: middle estimate off by 1.1-fold (0.03 log units), on the low side; the measured number falls inside the stated range.
By their numbers in this assay, from the lowest: compounds 1, 3 and 2 (each within the scatter of the next).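

In this assay, nitro on this aromatic carbon gives a 1.3-fold lower number from compound 2 to compound 3 (0.12 log units; within the scatter), and set against amino it gives a 1.5-fold higher number from compound 1 to compound 3 (0.17 log units; within the scatter). Within the data shown here, the earlier pair offered only two groups at this place; now a third, with 3 heavy atoms and 0 hydrogen-bond donors where sulfanyl has 1 heavy atom and 1 hydrogen-bond donor, still cannot be separated from either, so these three groups at this place are not told apart by this assay. Nothing shown gives a reason for this result.

Going by these compounds, whether a carboxylic acid or a methyl group on this aromatic carbon would separate from these three remains open. Also open, on these data alone, is whether a change elsewhere on the shared core, such as a longer chain in place of the isopropyl group, would move the number in this assay at all.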